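Removing the phenol from the benzyl arm of compound 2

This account rests on a few compounds, and the source may have more. Where it says the series, first, only, none or still open, it means among the compounds named here.

Measured so far:
compound 1, `COc1cccc(CNCCCNc2ccnc3cc(Oc4ccc(Cl)cc4)ccc23)c1O`, 9.28
compound 2, `COc1cccc(CNCCCNc2ccnc3cc(Cc4ccccc4)ccc23)c1O`, 9.47
compound 3, `COc1cccc(CNCCCNc2ccnc3cc(-c4ccccc4)ccc23)c1O`, 9.47

In a physicochemical assay for acid dissociation, compound 2 gives 9.47. It stands level with compound 3 at the digits shown, the two together the highest of the three numbers. The step of a number 0.19 log units higher from compound 1 to compound 2 (within the scatter) lies within the scatter, as do a number 0.19 log units higher from compound 1 to compound 3 (within the scatter) and no change at the digits printed from compound 2 to compound 3 (within the scatter). Every measured step exchanges the group on an aromatic carbon of the shared core, and none of them moves the number beyond the scatter.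

Compound 4, `COc1ccc(F)cc1CNCCCNc1ccnc2cc(Cc3ccccc3)ccc12`, has not yet been measured. It differs from compound 2 at another place: 5-fluoro-2-methoxyphenyl in place of 2-hydroxy-3-methoxyphenyl on a saturated chain carbon bound to an amine nitrogen. For the measured compounds named here, no measured step touches this part of the molecule, so the three measured compounds say nothing about how this change moves the number; they show only that the core substituent leaves it unchanged. The expectation for compound 4 therefore rests on compound 2 alone and carries a wide range. The expected step is a number 0.13 log units higher from compound 2 to compound 4 (within the scatter). Compound 4 is estimated at 9.6, with a range from 8.7 to 10.5.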

Compound 4, acid dissociation constant: 9.47
Beside the measured number, compound 4's estimate is 0.13 log units above it; the range from low to high includes it.
By their numbers in this assay, from the lowest: compounds 1, 2, 3 and 4 (each within the scatter of the next).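

In this assay, the first step measured at the saturated chain carbon bound to an amine nitrogen gives no change at the digits printed from compound 2 to compound 4 (within the scatter), so the exchange of 2-hydroxy-3-methoxyphenyl for 5-fluoro-2-methoxyphenyl stays within the scatter, as the exchanges on the shared core did. The entering group has no hydrogen-bond donor and the leaving group has one, so in this pair the number does not depend on that donor being present. Nothing available gives a reason for this result.

This single step alters the hydroxyl, the methoxy placement and the fluorine together, so the compounds shown do not separate their contributions. They also leave open what an amine or a carboxylic acid on this ring, or a longer chain between the two nitrogens, would do to the number.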